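Adding a Second Chloro to a Sulfur-Oxidized Core

The compounds below may be only part of what the source reports. "The series", "measured", "known", "first", "only" and "open" are said of these compounds alone.

Three small heterocycles have been tested in an assay on isolated protein for inhibition of histone acetyltransferase KAT2B (Homo sapiens), read by fluorescence, with a stated time of 15 min; a higher number here means a weaker inhibitor, a lower number a stronger inhibitor. Compound 1 `CCn1sc(Cl)cc1=O` gives 3000 nM. Compound 3 `CCn1sc(Cl)c(Cl)c1=O` carries one more chloro group, a change described as chloro in place of hydrogen on an aromatic carbon, and gives 2400 nM; the step of a 1.3-fold lower number from compound 1 to compound 3 (0.10 log units; within the scatter) shows that this extra chloro left the result essentially where it was.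

Compound 2 `CCn1c(=O)cc(Cl)[s+]1[O-]` has a different core, bearing an oxygen on the ring sulfur, and the difference between the two cores is not broken down here. In this assay compound 2 reaches only a limit, > 10000 nM, and not a number; it is the compound that sits at the limit of > 10000 nM in this assay, at which 1 of the 3 values shown sits.

Compound 4 `CCn1c(=O)c(Cl)c(Cl)[s+]1[O-]` has not yet been measured. It stands to compound 2 as compound 3 stands to compound 1: the change is chloro in place of hydrogen on an aromatic carbon. The two places are not identical word for word, since in compound 4 the new chloro is also two ring bonds from the ring atom that bears a group of 1 heavy atom, so this is the same kind of change rather than the same change.

Because the step of a 1.3-fold lower number from compound 1 to compound 3 (0.10 log units; within the scatter) lies within the scatter, compound 4 is expected to give 15000 nM. The expected step is a step that the limit leaves unreadable from compound 2 to compound 4. The estimated range for compound 4 runs from 6000 nM to 40000 nM, and a second limit rather than a number is the likelier outcome.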

Compound 4, half-maximal inhibitory concentration: > 10000 nM
Compound 4: a limit, no number; the forecaster's own chance of this, stated with the estimate: 80%; the middle value does not contradict the limit.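

In this assay compound 4 gives > 10000 nM, a limit and not a number. Compound 2 also stands at a limit, so the step between these two compounds cannot be read: the limit of > 10000 nM in this assay, at which 2 of the 4 values shown sit.

The compounds shown leave open how strongly compound 2 and compound 4 inhibit, and whether chloro in place of hydrogen changes the result on the core of compound 2.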